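A few compounds are considered here, and "the series" means these few. Any claim that something is new, unique, unknown or untested is made for them only; others in the source may bear on it.

Measured in a functional assay on PC-3 cells (Homo sapiens) for inhibition, read by MTT assay; on this read-out lower numbers stand for stronger inhibition and higher numbers for weaker inhibition:
- Compound 1 `COc1c(N2CCN(C)CC2)c(F)cc2c(=O)c(C(=O)N/N=C\c3ccc([N+](=O)[O-])cc3)cn(C3CC3)c12`: 15 ug/mL
- Compound 2 `COc1c(N2CCN(C)CC2)c(F)cc2c(=O)c(C(=O)N/N=C\c3cc(Br)ccc3O)cn(C3CC3)c12`: 12 ug/mL
- Compound 3 `COc1c(N2CCN(C)CC2)c(F)cc2c(=O)c(C(=O)N/N=C\c3ccc(O)cc3)cn(C3CC3)c12`: 14.4 ug/mL

Compound 3 cannot be separated from either of the other two, with a 1.0-fold lower number from compound 1 to compound 3 (0.02 log units; within the scatter) and a 1.2-fold higher number from compound 2 to compound 3 (0.08 log units; within the scatter). Compound 4 `COc1c(N2CCN(C)CC2)c(F)cc2c(=O)c(C(=O)N/N=C\c3ccccc3)cn(C3CC3)c12` carries hydrogen in place of hydroxy on an aromatic carbon, para to a large group (hydrogen in place of hydroxy on an aromatic carbon). The closest evidence is the exchange at that same carbon, where hydroxy replaced nitro, in a 1.0-fold lower number from compound 1 to compound 3 (0.02 log units; within the scatter). The larger aryl exchange, a 1.3-fold lower number from compound 1 to compound 2 (0.10 log units; within the scatter), also stayed within the scatter. No step beyond the scatter is therefore expected in this assay. The expected step is a 1.0-fold lower number from compound 3 to compound 4 (0.01 log units; within the scatter). For compound 4 the estimated value is 14 ug/mL, with an expected range from 8 ug/mL to 25 ug/mL.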

Compound 4, half-maximal inhibitory concentration: 16.3 ug/mL
Estimate against measurement, compound 4: 1.2-fold (0.07 log units) below; measured number inside the range.
By their numbers in this assay, from the lowest: compounds 2, 3, 1 and 4 (each within the scatter of the next).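

With hydrogen on this carbon, para to a large group, the phenyl compound cannot be separated in this assay from its hydroxy partner, a 1.1-fold higher number from compound 3 to compound 4 (0.05 log units; within the scatter), or from its nitro partner, a 1.1-fold higher number from compound 1 to compound 4 (0.04 log units; within the scatter). The earlier compounds shown here all carried a group on the aryl ring, and even the wider exchange of 5-bromo-2-hydroxyphenyl for phenyl stays within the scatter, a 1.4-fold higher number from compound 2 to compound 4 (0.13 log units; within the scatter). No evidence here bears on this result. Going by these compounds, whether an amine or a carboxylic acid on this carbon would give a step beyond the scatter remains open.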